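Moving the methyl around the phenoxy ring of compound 1

The source may hold more compounds than are shown below. What is called first, only, known or untested is meant among the compounds shown, and "the series" means these compounds.

Compound 1 `Cc1ccc(-c2csc(NC(=O)COc3ccccc3C)n2)cc1` is one of three measured analogues in a functional assay on MDA-MB-468 cells (Homo sapiens) for cytotoxicity, read by MTT assay, with a stated time of 48 h; a higher number here means a weaker inhibitor, a lower number a stronger inhibitor. Compound 1 gives 52100 nM. Compound 2 `Cc1ccc(-c2csc(NC(=O)COc3ccccc3C(C)C)n2)cc1` gives 55500 nM and compound 3 `Cc1ccccc1OCC(=O)Nc1nc(-c2ccc(Cl)cc2)cs1` gives 40100 nM, so compound 1 sits between them, and every gap among the three is within the scatter: a 1.1-fold higher number from compound 1 to compound 2 (0.03 log units; within the scatter) and a 1.3-fold lower number from compound 1 to compound 3 (0.11 log units; within the scatter).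

Compound 4 `Cc1ccc(OCC(=O)Nc2nc(-c3ccc(C)cc3)cs2)cc1` has not yet been measured. It differs from compound 1 by 4-methylphenyl in place of 2-methylphenyl on an oxygen on a saturated carbon; the same difference, cut one bond further out, reads 2-methylphenoxy to 4-methylphenoxy. Neither measured step alters this place of the shared core in the same way. The step from compound 1 to compound 2 changes the size of the group on that ring and stays within the scatter, while the step from compound 1 to compound 3 concerns the other aromatic ring. With nothing in these data pointing either way, compound 4 is expected to show no step beyond the scatter, a 1.0-fold lower number from compound 1 to compound 4 (0.02 log units; within the scatter). Compound 4 is therefore estimated at 50000 nM, with a range from 25000 nM to 100000 nM.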

Compound 4, half-maximal inhibitory concentration: 37200 nM
Compound 4: the middle estimate sits 1.3-fold (0.13 log units) above what was measured; the range from low to high includes it.
By their numbers in this assay, from the lowest: compounds 4, 3, 1 and 2 (each within the scatter of the next).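

Compound 4 keeps the same atoms as compound 1, with 4-methylphenyl in place of 2-methylphenyl on the oxygen, and in this assay this gives a 1.4-fold lower number from compound 1 to compound 4 (0.15 log units; within the scatter). The earlier steps shown here changed which group stood on an aromatic carbon, whereas this one changes only how the same atoms are joined, and the result also stays within the scatter, as did a 1.1-fold higher number from compound 1 to compound 2 (0.03 log units; within the scatter). No measurement here bears on this result or accounts for it.

Going by these compounds, whether an amine or a carboxylic acid in place of the methyl on this phenoxy ring would move the number beyond the scatter remains open. On these data alone, it is also open whether 4-methylphenoxy would give a similar number with the chloro group of compound 3 on the other aromatic ring.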